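A few compounds are considered here, and "the series" means these few. Any claim that something is new, unique, unknown or untested is made for them only; others in the source may bear on it.

Measured compounds in a functional assay on CCRF-CEM cells (Homo sapiens) for cytotoxicity, in the absence of a further agent; on this read-out higher numbers stand for weaker inhibition and lower numbers for stronger inhibition:
Compound 1 `COC(=O)c1ccc(CN(CCCc2c(N)nc(N)nc2O)c2cc(F)cc(F)c2[N+](=O)[O-])cc1` gives > 100000 nM, a limit of this assay.
Compound 2 `Nc1nc(N)c(CCCNc2cc(F)cc(F)c2[N+](=O)[O-])c(O)n1` gives 97000 nM.
Compound 3 `COC(=O)c1ccc(CN(CCCc2c(N)nc(N)nc2O)c2ccc([N+](=O)[O-])c(F)c2F)cc1` gives 45000 nM.

Compound 1 sits at the limit of > 100000 nM in this assay, at which 1 of the 3 values shown sits. Compound 2 differs from compound 1 by hydrogen in place of 4-(methoxycarbonyl)benzyl on a nitrogen on an aromatic ring, and this gave an at least 1.0-fold lower number from compound 1 to compound 2 (0.01 log units; that floor lies within the scatter). Compound 3 differs from compound 1 in its core, by 2,3-difluoro-4-nitrophenyl in place of 3,5-difluoro-2-nitrophenyl on an amine nitrogen, and this gave an at least 2.2-fold lower number from compound 1 to compound 3 (0.34 log units; beyond the scatter). Compound 3 stands lowest of the two numbers in this assay.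

Compound 4 `Nc1nc(N)c(CCCNc2ccc([N+](=O)[O-])c(F)c2F)c(O)n1` has not yet been measured. It differs from compound 3 by hydrogen in place of 4-(methoxycarbonyl)benzyl on a nitrogen on an aromatic ring, the same change as that from compound 1 to compound 2, with the same neighbours at the place. Because the earlier step was an at least 1.0-fold lower number from compound 1 to compound 2 (0.01 log units; that floor lies within the scatter), only a small step is expected: compound 4 is expected to show a 1.1-fold lower number from compound 3 to compound 4 (0.05 log units; within the scatter). Compound 4 is therefore estimated at 40000 nM, most likely between 15000 nM and 100000 nM.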

Compound 4, half-maximal inhibitory concentration: 68000 nM
Estimate against measurement, compound 4: 1.7-fold (0.23 log units) below; low and high end bracket the measured number.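

In this assay, hydrogen in place of 4-(methoxycarbonyl)benzyl gave a 1.5-fold higher number from compound 3 to compound 4 (0.18 log units; within the scatter), so on this core the change does not separate the two compounds. Set beside the earlier step, the same change now stands on two cores: the same change on two cores in this assay, an at least 1.0-fold lower number (0.01 log units; that floor lies within the scatter) from compound 1 to compound 2 and a 1.5-fold higher number (0.18 log units; within the scatter) from compound 3 to compound 4; the limit leaves it open whether they differ. Going by these compounds, compound 1 gives > 100000 nM, which is a limit of the assay, so the size of the step on its core stays unknown and the data do not show that the change carries over unaltered.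

The compounds shown leave open whether a benzyl group carrying a carboxylic acid in place of the methyl ester would behave the same way on either core. They also leave open what a longer chain would do.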